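The compounds below may be only part of what the source reports. "The series", "measured", "known", "first", "only" and "open" are said of these compounds alone.

Among the measured compounds shown here, compound 2, `N#Cc1ccc(OCCCCCn2ccc(=O)[nH]c2=O)cc1`, is the only member of this small set for which an ADME assay on HEL cells (Homo sapiens) for cytotoxicity, read by microscopy (a lower number here means that less compound is tolerated, a higher number that more compound is tolerated), reports a number rather than a limit: compound 2 gives 100000 nM. Compound 1, `O=C(O)c1ccc(OCCCCCn2ccc(=O)[nH]c2=O)cc1`, carries a carboxy group where compound 2 carries a cyano group. In this assay compound 1 reaches only a limit of the assay, > 100000 nM. For the measured compounds named here, the one measured step, a number no higher from compound 1 to compound 2 (the limit leaves the size open), therefore cannot be sized, because one end of it sits at the limit of > 100000 nM in this assay, at which 1 of the 2 values shown sits.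

Compound 3, `O=c1ccn(CCCCCOc2ccccc2)c(=O)[nH]1`, is not yet measured. It differs from compound 2 in one place: hydrogen in place of cyano on an aromatic carbon. Going by the values given here, no measured step shows what removing a cyano group does, so the only guide is that compound 2 and compound 1 both sit at or beyond the same high concentration in this assay. A step from compound 2 to compound 3 no larger than the ordinary scatter is expected, that is no change at the digits printed from compound 2 to compound 3 (within the scatter). For compound 3 the estimated value in this assay is 100000 nM, most likely within 50000 nM to 200000 nM, with a fair chance that only a limit is reported.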

Compound 3, minimum cytotoxic concentration: > 100000 nM
Compound 3: no number, only a limit; the forecaster's own chance of this, stated with the estimate: 50%; the middle value sits exactly at the limit.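

In this assay compound 3 gives > 100000 nM, which is a limit of the assay and not a number. With the cyano group replaced by hydrogen, the result is a number no lower from compound 2 to compound 3 (the limit leaves the size open), so the aromatic carbon para to a large group can now be seen to carry no substituent at all without a number appearing in this assay. None of the steps among these compounds can be sized, because at least one end of each sits at a limit: the limit of > 100000 nM in this assay, at which 2 of the 3 values shown sit.

The compounds shown leave open how far beyond the limit compound 1 and compound 3 lie, so they cannot be ranked against each other. They also leave open whether an amine at this position, or a longer chain in the linker, would give a clearly lower number in this assay.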